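A Methyl for a Trifluoromethyl on the Fused Core

The source may report more compounds than this note shows. Statements on the series, on what has been measured and on what is new or still open speak of the compounds shown alone.

Compound 1 `Nc1nc2ccccn2c1-c1ccc(O)cc1`: > 100000 nM, a limit of the assay.
Compound 2 `Nc1nc2c(C(F)(F)F)cccn2c1-c1ccc(O)cc1`: > 100000 nM, a limit of the assay.
Compound 3 `Cc1ccc2nc(N)c(-c3ccc(O)cc3)n2c1`: > 100000 nM, a limit of the assay.

In an assay on isolated protein for inhibition of ubiquitin carboxyl-terminal hydrolase 47 (Homo sapiens) (a higher number here means a weaker inhibitor, a lower number a stronger inhibitor), compound 2 stands only at a limit, > 100000 nM. Compound 4 `Cc1cccn2c(-c3ccc(O)cc3)c(N)nc12` differs from it by methyl in place of trifluoromethyl on an aromatic carbon. The step that the two limits leave unreadable from compound 1 to compound 2 concerns the same position and the step that the two limits leave unreadable from compound 1 to compound 3 the same entering group, yet neither can be read, since every value sits at the limit of > 100000 nM in this assay, at which 3 of the 3 values shown sit. The data give no hint of a measurable number anywhere in this series. Compound 4 is therefore estimated at 150000 nM, within 50000 nM to 500000 nM, most likely reported again as a limit. The step that the limit leaves unreadable from compound 2 to compound 4 is expected to be none beyond the scatter.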

Compound 4, half-maximal inhibitory concentration: > 100000 nM
Compound 4: no number, only a limit; the forecaster's own chance of this, stated with the estimate: 85%; the middle value lies beyond the limit too.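

No new step can be read from compound 2 to compound 4 or from compound 1 to compound 4, since each of these values is only a limit: the limit of > 100000 nM in this assay, at which 4 of the 4 values shown sit.

The compounds shown leave open whether any change on the shared core gives a measurable number in this assay at all.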